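One more carbon on the chain at the ring nitrogen

The compounds below may be only part of what the source reports. "The series", "measured", "known", "first", "only" and "open" are said of these compounds alone.

Compound 2 `CCCCCNc1cccc(NC(=O)c2ccc(OCCC)cc2)n1` stands at a limit in an in vitro assay on HEK-tsA201 cells for antagonist activity at Neuronal acetylcholine receptor; alpha3/beta4 (Homo sapiens), read by fluorescence and calcium flux; on this read-out lower numbers stand for stronger inhibition and higher numbers for weaker inhibition: compound 2 gives > 100000 nM, which is a limit of the assay and not a number. Compound 1 `CCCNc1cccc(NC(=O)c2ccc(OCCC)cc2)n1` gives 12600 nM. Among the measured compounds shown here, the one measured step, an at least 7.9-fold higher number from compound 1 to compound 2 (0.89 log units; beyond the scatter), runs toward weaker inhibition and ends at the limit of > 100000 nM in this assay, at which 1 of the 2 values shown sits. Compound 3 `CCCCCCNc1cccc(NC(=O)c2ccc(OCCC)cc2)n1` carries methyl in place of hydrogen on a saturated chain carbon, five bonds along the chain from a nitrogen on an aromatic ring, a change of the same kind, so no return below the limit is expected. Compound 3 is expected to give 200000 nM, in the range 60000 nM to 700000 nM. That estimate means a step that the limit leaves unreadable from compound 2 to compound 3.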

Compound 3, half-maximal inhibitory concentration: > 100000 nM
Compound 3: a limit, no number (the forecaster's own chance of this, stated with the estimate: 85%); the middle value is on the limit's open side.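

Compound 3 gives > 100000 nM in this assay, which is a limit of the assay and not a number, so adding methyl to the chain brings no return from the limit. Against the shorter chain, the result is an at least 7.9-fold higher number from compound 1 to compound 3 (0.89 log units; beyond the scatter), so the loss seen with the pentyl-length chain of compound 2 also holds for this longer chain. The step between compound 2 and compound 3 cannot be read: the limit of > 100000 nM in this assay, at which 2 of the 3 values shown sit.

Still open, from the compounds shown here alone, is whether a chain shorter than that of compound 1, such as ethyl, or a chain carrying a hydroxyl or an amine at this position, would give stronger inhibition than compound 1.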